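Isoxazole-fused acid: pyridinyloxy replaces trifluoromethyl

The compounds below may be only part of what the source reports. "The series", "measured", "known", "first", "only" and "open" are said of these compounds alone.

Compound 3 `O=C(O)c1ccc2noc(-c3cccc(C(F)(F)F)c3)c2c1` carries a trifluoromethyl group on its six-membered aromatic ring of carbon only. For the measured compounds named here, in an assay for inhibition of inositol hexakisphosphate kinase 2 (Homo sapiens), read by colorimetric assay, coupled enzyme assay and malachite green, with a stated time of 120 min, in the presence of a further agent that is not named here (on this read-out lower numbers stand for stronger inhibition and higher numbers for weaker inhibition), compound 3 gives 1460 nM, the highest of the three numbers measured so far. Compound 1 `O=C(O)c1ccc2noc(-c3ccc(N4CCCCC4)cc3)c2c1` gives 240 nM in this assay, and compound 2 `O=C(O)c1ccc2noc(-c3ccc(Oc4ccccn4)cc3)c2c1` gives 1190 nM; the values of compound 2 and compound 3 lie within the usual scatter of each other, while compound 1 stands clearly apart from both.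

Compound 4 `O=C(O)c1ccc2noc(-c3cccc(Oc4ccccn4)c3)c2c1` differs from compound 3 in one place: (pyridin-2-yl)oxy in place of trifluoromethyl on an aromatic carbon. Going by the values given here, the only measured step touching the entering group is a 5.0-fold higher number from compound 1 to compound 2 (0.70 log units; beyond the scatter), where (pyridin-2-yl)oxy replaced piperidin-1-yl rather than trifluoromethyl, so it does not directly mirror the present change. Among the compounds with values here, no measured step starts from a trifluoromethyl group. What remains is that compound 2, which bears the same (pyridin-2-yl)oxy group, sits within the scatter of compound 3 in this assay.

On that basis compound 4 is expected to give about 1200 nM in this assay, between 400 nM and 3600 nM. The expected step is a 1.2-fold lower number from compound 3 to compound 4 (0.09 log units; within the scatter), that is, no movement beyond the scatter.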

Compound 4, half-maximal inhibitory concentration: 690 nM
Compound 4: middle estimate off by 1.7-fold (0.24 log units), on the high side; low and high end bracket the measured number.
By their numbers in this assay, from the lowest: compound 1; then compounds 4, 2 and 3 (each within the scatter of the next, the first and the last beyond it).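

In this assay, for the compounds shown here, a 2.1-fold lower number from compound 3 to compound 4 (0.33 log units; beyond the scatter), the first measured step that starts from trifluoromethyl. It shows that on this aromatic carbon, meta to a large group, the change to (pyridin-2-yl)oxy brings in a six-membered aromatic ring and more heavy atoms, yet the number still moves modestly downward rather than upward. Compound 2 carries the same (pyridin-2-yl)oxy group elsewhere on that carbon ring and gives 1190 nM, while compound 4 gives 690 nM, so these two lie within the scatter of each other and this assay does not separate the two placements; no measured evidence bears on the reason for the step.

The compounds shown do not tell whether the ring nitrogen of the pyridine or its ether oxygen matters for the step, which a phenoxy group or a benzyl group on the same carbon would address. They also leave open whether piperidin-1-yl, the group of compound 1 at 240 nM, or another amine such as morpholine would give a lower number at this place.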